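The source may hold more compounds than are shown below. What is called first, only, known or untested is meant among the compounds shown, and "the series" means these compounds.

Two compounds have been measured so far in a functional assay on SGC-7901 cells (Homo sapiens) for inhibition, read by MTT assay, with a stated time of 24 h (on this read-out higher numbers stand for weaker inhibition and lower numbers for stronger inhibition), as follows:
- compound 1 `CC1(C)[C@H]2CC[C@]1(C)N(Cc1cn(-c3cccc(Cl)c3)nn1)C(=O)C2` gives 510 nM in this test
- compound 2 `CC1(C)[C@H]2CC[C@]1(C)N(Cc1cn(-c3ccc(O)cc3)nn1)C(=O)C2` gives 330 nM in this test

Among the compounds with values here, compound 2 stands within the scatter of compound 1, the only other measured compound. The unmeasured compound 3 `CC1(C)[C@H]2CC[C@]1(C)N(Cc1cn(-c3ccccc3O)nn1)C(=O)C2` has the same atoms as compound 2, joined differently, with 2-hydroxyphenyl in place of 4-hydroxyphenyl on an aromatic nitrogen. Within the data shown here, the one measured step is a 1.5-fold lower number from compound 1 to compound 2 (0.19 log units; within the scatter) and it exchanges 3-chlorophenyl for 4-hydroxyphenyl on that same nitrogen. Among the measured compounds shown here, no measured compound carries 2-hydroxyphenyl, so this step is only a limited guide. On this evidence the expected result is a 1.2-fold higher number from compound 2 to compound 3 (0.08 log units; within the scatter) and no step beyond the scatter is expected. In this assay compound 3 is estimated at 400 nM within an expected range (150 nM to 1100 nM).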

Compound 3, half-maximal inhibitory concentration: 410 nM
Estimate against measurement, compound 3: 1.0-fold (0.01 log units) below; measured number inside the range.
By their numbers in this assay, from the lowest: compounds 2, 3 and 1 (each within the scatter of the next).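

In this assay, 2-hydroxyphenyl in place of 4-hydroxyphenyl on the aromatic nitrogen gives a 1.2-fold higher number from compound 2 to compound 3 (0.09 log units; within the scatter) and so shows that, for these two placements of the hydroxyl group, this assay does not separate the isomers. Set against 3-chlorophenyl, 2-hydroxyphenyl gives a 1.2-fold lower number from compound 1 to compound 3 (0.09 log units; within the scatter) at the same nitrogen. Within the data shown here, all three aryl groups at this position therefore lie within the scatter of one another, which the single earlier step could not show for an isomer pair. Nothing available here accounts for this result. On these data alone, it remains open whether 3-hydroxyphenyl or unsubstituted phenyl would fall in the same range. As far as these compounds go, it is also open whether an amine or a carboxylic acid on the phenyl ring, or a longer alkyl chain in its place, would give a step beyond the scatter.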